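This account rests on a few compounds, and the source may have more. Where it says the series, first, only, none or still open, it means among the compounds named here.

Measured so far in a functional assay on VCaP cells (Homo sapiens) for antiproliferative activity, read by propidium iodide staining, with a stated time of 96 h; a lower number here means a stronger inhibitor, a higher number a weaker inhibitor: compound 1 `CC(O)(CS(=O)(=O)c1cccc(S(F)(F)(F)(F)F)c1)C(=O)Nc1ccc(C#N)cc1C(F)(F)F` gives 20800 nM; compound 2 `CC(O)(CS(=O)(=O)c1cccc(S(F)(F)(F)(F)F)c1)C(=O)Nc1ccc([N+](=O)[O-])cc1C(F)(F)F` gives 100000 nM; compound 3 `CC1(C)C(=O)N(c2ccc(C#N)cc2C(F)(F)F)C(=S)N1c1cccc(S(F)(F)(F)(F)F)c1` gives 100000 nM.

Compound 1 and compound 2 share one core; compound 3 is built on another, and the difference between the two cores is not broken down here. Within the first core the change nitro in place of cyano on an aromatic carbon gave a 4.8-fold higher number from compound 1 to compound 2 (0.68 log units; beyond the scatter). Compound 4 `CC1(C)C(=O)N(c2ccc([N+](=O)[O-])cc2C(F)(F)F)C(=S)N1c1cccc(S(F)(F)(F)(F)F)c1` carries the same change on the core of compound 3: nitro in place of cyano on an aromatic carbon. Compound 3 stands level with compound 2, and both give higher numbers than compound 1.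

In this assay compound 4 is expected to show a step of about no change at the digits printed from compound 3 to compound 4 (within the scatter), because compound 3 already gives 100000 nM and the same change gave a 4.8-fold higher number from compound 1 to compound 2 (0.68 log units; beyond the scatter) within the other core. Compound 4 is estimated at 100000 nM in this assay, with a range from 50000 nM to 300000 nM.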

Compound 4, half-maximal inhibitory concentration: 100000 nM
The estimate for compound 4 equals the measured number at the digits printed; measured number inside the range.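

Nitro in place of cyano on an aromatic carbon gives no change at the digits printed from compound 3 to compound 4 (within the scatter) in this assay. The size of the step did not carry over from one core to the other: the same change on two cores in this assay, a 4.8-fold higher number (0.68 log units; beyond the scatter) from compound 1 to compound 2 and no change at the digits printed (within the scatter) from compound 3 to compound 4, 4.8-fold (0.68 log units) apart, beyond the scatter of two such steps
This rests on a single pair per core: it shows that the step depends on the core for these four compounds, but not why, nor which step a further core would follow.

Still open, from the compounds shown here alone, is how either core responds to other groups on that aromatic carbon, such as an amine or a carboxylic acid. Also open, going by these compounds, is the effect of a longer chain in place of the trifluoromethyl group.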